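Diisopropylamino for Diethylamino on a Long-Chain Carbamate

The source may hold more compounds than are shown below. What is called first, only, known or untested is meant among the compounds shown, and "the series" means these compounds.

Compound 1 `CCCCCCCCCCCCCC[C@H](OCOC)[C@H](CO)NC(=O)OC(C)(C)C`: 25.9%
Compound 2 `CCCCCCCCCCCCCC[C@H](OCOC)[C@H](CN(CC)CC)NC(=O)OC(C)(C)C`: 27.5%

In a functional assay on A549 cells (Homo sapiens) for antiproliferative activity, read by sulforhodamine B assay, with a stated time of 48 h, tested at 10 uM (a higher number here means more inhibition at the concentration tested (going by the name of the read-out), a lower number less inhibition), compound 1 gives 25.9% and compound 2 gives 27.5%. The step of a number 1.6 percentage points higher from compound 1 to compound 2 (within the scatter) is within the scatter, so compound 2 stands apart from nothing; the two numbers are indistinguishable. Compound 3 `CCCCCCCCCCCCCC[C@H](OCOC)[C@H](CN(C(C)C)C(C)C)NC(=O)OC(C)(C)C` differs from compound 2 by diisopropylamino in place of diethylamino on a saturated chain carbon, two bonds along the chain from an amide-type nitrogen. Going by the values given here, no measured step exchanges one amine for another; the only step, a number 1.6 percentage points higher from compound 1 to compound 2 (within the scatter), concerns the arrival of diethylamino and was within the scatter. Compound 3 is therefore expected to move by a number 0.5 percentage points higher from compound 2 to compound 3 (within the scatter), nothing beyond the scatter. The estimate for compound 3 is 28%, between 15% and 42%.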

Compound 3, a percentage reported as inhibition, at one concentration (the size of the read-out at that concentration, not a potency): 22.6%
Compound 3: middle estimate off by 5.4 percentage points, on the high side; low and high end bracket the measured number.
By their numbers in this assay, from the lowest: compounds 3, 1 and 2 (each within the scatter of the next).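

In this assay, going by these compounds alone, diisopropylamino in place of diethylamino on a saturated chain carbon, two bonds along the chain from an amide-type nitrogen, gives a number 4.9 percentage points lower from compound 2 to compound 3 (within the scatter) and so offers the first exchange of one amine for another at this position, with no readable difference. Diisopropylamino in place of hydroxy at the same carbon gives a number 3.3 percentage points lower from compound 1 to compound 3 (within the scatter) and so, like diethylamino, does not set the amine apart from the hydroxy compound. From the compounds shown here alone, whether a piperidine or morpholine ring or a primary amine on this carbon would stay in the same range remains open. Nothing at hand accounts for these numbers.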